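This account rests on a few compounds, and the source may have more. Where it says the series, first, only, none or still open, it means among the compounds named here.

Measured so far:
compound 1 `Cc1cc(C)nc(N(CCN(C)C)C(=O)N(C)C)c1` gives 58% in a functional assay on the whole organism (stomach) for inhibition, with Canis familiaris (Canis lupus familiaris) as the target, at a dose of 40 mg/kg by the oral route; a lower number here means a weaker effect, a higher number a stronger effect of the compound at the dose given
compound 2 `CCCN(CCC)CCN(C(=O)N(C)C)c1cc(C)cc(C)n1` gives 93% in this assay
compound 3 `CC(C)N(CCN(C(=O)N(C)C)c1ccccn1)C(C)C` gives 82% in this assay

Compound 3 stands second highest of the three numbers in this assay: compound 2 sits above it and compound 1 below it, both gaps beyond the scatter. Compound 4 `Cc1ccc(N(CCN(C(C)C)C(C)C)C(=O)N(C)C)nc1` differs from compound 3 by methyl in place of hydrogen on an aromatic carbon. Going by the values given here, the only measured step, a number 35 percentage points higher from compound 1 to compound 2 (beyond the scatter), concerns the amine on the chain, not the ring, so no measured step bears on a methyl in place of hydrogen on an aromatic carbon. Nothing in the series therefore points to a step beyond the scatter in this assay. Compound 4 is expected to give about 80%, between 65% and 92%. The step of a number 2 percentage points lower from compound 3 to compound 4 (within the scatter) is expected to stay within the scatter.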

Compound 4, a percentage reported as inhibition, in the whole organism at one dose (the size of the read-out at that dose, not a potency): 33%
Compound 4: the middle estimate sits 47 percentage points above what was measured; measured number outside the range, below it.
By their numbers in this assay, from the lowest: compound 4; then compound 1; then compound 3; then compound 2.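

In this assay the change from pyridin-2-yl to 5-methylpyridin-2-yl gives a number 49 percentage points lower from compound 3 to compound 4 (beyond the scatter) and shows that this ring position, on an aromatic carbon para to a large group, is not neutral at this dose. Even a single added methyl there is enough for a large step, which the earlier step on the chain amine could not show. No available evidence accounts for this step.

The compounds shown leave open whether the loss is specific to methyl or also follows with a chlorine atom, a methoxy group or an ethyl group at this position. They also leave open whether the same step appears with dipropylamino on the chain.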